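A few compounds are considered here, and "the series" means these few. Any claim that something is new, unique, unknown or untested is made for them only; others in the source may bear on it.

Measured in a functional assay on PANC-1 cells (Homo sapiens) for cytotoxicity, read by WST assay, with a stated time of 24 h; on this read-out lower numbers stand for stronger inhibition and higher numbers for weaker inhibition:
- Compound 1 `O=C(CCCCCCCCc1ccccc1)N1CCCCC1`: > 100000 nM, a limit of the assay
- Compound 2 `O=C(CCCCCCCCCc1ccccc1)N1CCCCC1`: > 100000 nM, a limit of the assay

Compound 2 has no actual number yet. Its > 100000 nM is only a limit of the assay, so it shows that no half-maximal inhibitory concentration could be read. The same is true across the whole small set: the limit of > 100000 nM in this assay, at which 2 of the 2 values shown sit.

The next compound, compound 3 `O=C(CCCCCCCCCCc1ccccc1)N1CCCCC1`, differs from compound 2 as follows: benzyl in place of phenyl on a saturated chain carbon, nine bonds along the chain from a carbonyl carbon. In words, this is benzyl in place of phenyl on a saturated chain carbon, nine bonds along the chain from a carbonyl carbon.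

Among the measured compounds shown here, one measured step bears on this change, since it is the same swap made eight bonds along the chain: a step that the two limits leave unreadable from compound 1 to compound 2. That step has no readable size, so it offers no trend to extend. With no sign of activity so far, no change beyond the scatter is expected in this assay, and a further limit is the likeliest result. The expected step is a number no higher from compound 2 to compound 3 (the limit leaves the size open). For compound 3 the estimated value is 100000 nM, with an expected range from 50000 nM to 200000 nM.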

Compound 3, half-maximal inhibitory concentration: > 100000 nM
Compound 3 ended at the assay's limit (the forecaster's own chance of this, stated with the estimate: 85%); the middle value sits exactly at the limit.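

No step among compound 1, compound 2 and compound 3 can be read, because all three values are limits of the assay rather than numbers: the limit of > 100000 nM in this assay, at which 3 of the 3 values shown sit.

The compounds shown leave open whether any change to the chain or the shared core would give a readable half-maximal inhibitory concentration in this assay.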